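Bromo for methyl on two indole-bearing cores

The source may report more compounds than this note shows. Statements on the series, on what has been measured and on what is new or still open speak of the compounds shown alone.

Compound 1 `COC(=O)[C@@]1(C)CCC=C2[C@@H]1CC[C@@H](C)[C@]2(C)Cc1c[nH]c2ccc(C)cc12` gives 20000 nM in a functional assay on T47D cells (Homo sapiens) for inhibition, read by sulforhodamine B assay, with a stated time of 48 h; a higher number here means a weaker inhibitor of growth, a lower number a stronger inhibitor of growth. Compound 2 `COC(=O)[C@@]1(C)CCC=C2[C@@H]1CC[C@@H](C)[C@]2(C)Cc1c[nH]c2ccc(Br)cc12` gives 16000 nM in this assay. The change bromo in place of methyl on an aromatic carbon made the step of a 1.3-fold lower number from compound 1 to compound 2 (0.10 log units; within the scatter). Compound 3 `COC(=O)[C@@]1(C)CC[C@@H]2C3=C1CC[C@@H](C)[C@]3(C)Cc1c2[nH]c2c(C)cccc12` gives 23000 nM in this assay. The difference between the core of compound 1 and the core of compound 3 is not broken down here. Compound 4 `COC(=O)[C@@]1(C)CC[C@@H]2C3=C1CC[C@@H](C)[C@]3(C)Cc1c2[nH]c2c(Br)cccc12` carries the same kind of change relative to compound 3: bromo in place of methyl on an aromatic carbon. The place differs: in compound 2 the ring is part of a fused or bridged system of two rings, meta to a fused ring and para to a fused ring, whereas in compound 4 it is part of a fused or bridged system of five rings, ortho to a fused ring and meta to a fused ring. Because the earlier step of a 1.3-fold lower number from compound 1 to compound 2 (0.10 log units; within the scatter) stayed within the scatter, the step is expected to be a 1.3-fold lower number from compound 3 to compound 4 (0.11 log units; within the scatter). Compound 4 is estimated at 18000 nM, expected between 9000 nM and 40000 nM.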

Compound 4, concentration for 50% growth inhibition: 31000 nM
Compound 4: the middle estimate sits 1.7-fold (0.24 log units) below what was measured; measured number inside the range.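

Bromo in place of methyl on an aromatic carbon gives a 1.3-fold higher number from compound 3 to compound 4 (0.13 log units; within the scatter) in this assay. Set beside the earlier step, the change carries from one core to the other with no difference that can be told from scatter: the same change on two cores in this assay, a 1.3-fold lower number (0.10 log units; within the scatter) from compound 1 to compound 2 and a 1.3-fold higher number (0.13 log units; within the scatter) from compound 3 to compound 4, 1.7-fold (0.23 log units) apart, within the scatter of two such steps. For the compounds shown here, this shows only that the swap leaves the number within scatter at these two places on these two cores; it gives no direction for the change and does not show that it would behave alike on another core or at another place.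

Still open, from the compounds shown here alone, is whether a different group at these places, such as an amine or a carboxylic acid, would move the number beyond the scatter. Also open, going by these compounds, is what an amide in place of the methyl ester would do on either core.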